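The source may report more compounds than this note shows. Statements on the series, on what has been measured and on what is new or still open speak of the compounds shown alone.

Compound 3 `COc1ccc(-n2ccc(=O)c(C(=O)Nc3ccc(Oc4ccnc5c4ccn5C)cc3)n2)cc1` was tested in a functional assay on MCF7 cells (Homo sapiens) for cytotoxicity, read by MTT assay, with a stated time of 72 h; a lower number here means a stronger inhibitor, a higher number a weaker inhibitor. In this assay compound 3 gives only a limit, > 60000 nM. Compound 1 `COc1ccc(-n2ccc(=O)c(C(=O)Nc3ccc(Oc4ccnc5[nH]ccc45)cc3)n2)cc1` carries hydrogen where compound 3 carries methyl on an aromatic nitrogen; in this assay compound 1 gives 21600 nM. The step from compound 1 to compound 3 is an at least 2.7-fold higher number from compound 1 to compound 3 (0.44 log units; beyond the scatter), so compound 3 stands at the weak end of what has been measured. Compound 2 `O=C(Nc1ccc(Oc2ccnc3[nH]ccc23)c(F)c1)c1nn(-c2ccc(Cl)cc2)ccc1=O` also belongs to the set. In this assay compound 2 gives only a limit, > 60000 nM. Two of the three values thus sit at the limit of > 60000 nM in this assay, at which 2 of the 3 values shown sit.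

Compound 4 `Cn1ccc2c(Oc3ccc(NC(=O)c4nn(-c5ccc(Br)cc5F)ccc4=O)cc3)ccnc21` differs from compound 3 by 4-bromo-2-fluorophenyl in place of 4-methoxyphenyl on an aromatic nitrogen. Among the measured compounds shown here, no measured step concerns this change; the single measured step, from compound 1 to compound 3, lies at a different place, and compound 2, which carries a halogenated aryl on the same nitrogen, gives only a limit. Compound 4 is therefore expected to give about 80000 nM, between 20000 nM and 300000 nM, most likely as a limit. The expected step, a step that the limit leaves unreadable from compound 3 to compound 4, is none beyond the scatter.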

Compound 4, half-maximal inhibitory concentration: 19800 nM
Beside the measured number, compound 4's estimate is 4.0-fold (0.61 log units) above it; the measured number lies below the stated range.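

In this assay, the aryl group on this aromatic nitrogen can shift the read-out: 4-bromo-2-fluorophenyl in place of 4-methoxyphenyl gives an at least 3.0-fold lower number from compound 3 to compound 4 (0.48 log units; beyond the scatter). This is the first step shown at this position, as the only earlier step lay at a different place, and it gives the first exact value among the compounds with methyl on the aromatic nitrogen of the core. The true size of the step remains unknown, as the value of compound 3 is only a limit: the limit of > 60000 nM in this assay, at which 2 of the 4 values shown sit.

The compounds shown do not separate the contributions of bromine and fluorine, since 4-bromophenyl and 2-fluorophenyl do not appear alone on this nitrogen. They also leave open how an amine or a carboxylic acid on this aryl ring would read.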